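Swapping the Aryl Group on Compound 3

The source may report more compounds than this note shows. Statements on the series, on what has been measured and on what is new or still open speak of the compounds shown alone.

- Compound 1 `CC(C)[C@H](NC(=O)COc1cccc2ccccc12)C(=O)N[C@@H](CC(=O)O)C(=O)COc1ccc2ccccc2c1`: > 100000 nM (a limit)
- Compound 2 `CC(C)[C@H](NC(=O)COc1cccc2ccccc12)C(=O)N[C@@H](CC(=O)O)C(=O)COc1ccccc1[N+](=O)[O-]`: > 100000 nM (a limit)
- Compound 3 `CC(C)[C@H](NC(=O)COc1cccc2ccccc12)C(=O)N[C@@H](CC(=O)O)C(=O)COc1c(F)cc(F)cc1F`: 6840 nM

In a functional assay on Jurkat cells (Homo sapiens) (a higher number here means a weaker inhibitor, a lower number a stronger inhibitor), compound 3 is the only one of the three with an actual number, 6840 nM. The other two readings are limits of the assay, not numbers: the limit of > 100000 nM in this assay, at which 2 of the 3 values shown sit.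

Compound 4 `CC(C)[C@H](NC(=O)COc1cccc2ccccc12)C(=O)N[C@@H](CC(=O)O)C(=O)COc1cccc(C(F)(F)F)c1F` keeps the shared core and changes one group: 2-fluoro-3-(trifluoromethyl)phenyl in place of 2,4,6-trifluorophenyl on an oxygen on a saturated carbon. Here 2-fluoro-3-(trifluoromethyl)phenyl takes the place of 2,4,6-trifluorophenyl on an oxygen on a saturated carbon.

Two measured steps change this same group: an at least 14-fold lower number from compound 1 to compound 3 (1.16 log units; beyond the scatter) and an at least 14-fold lower number from compound 2 to compound 3 (1.16 log units; beyond the scatter). Both are large and beyond the scatter, so a swap here can matter greatly. The third step, a step that the two limits leave unreadable from compound 1 to compound 2, cannot be read. Leaving the 2,4,6-trifluorophenyl group of compound 3 is therefore expected to give a moderate rise in the number, meaning a weaker inhibitor, and the limit could be reached. The expected change is a 2.9-fold higher number from compound 3 to compound 4 (0.47 log units; beyond the scatter). For compound 4, the estimated value is 20000 nM, with an expected range of 6000 nM to 70000 nM.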

Compound 4, half-maximal inhibitory concentration: 50400 nM
Estimate against measurement, compound 4: 2.5-fold (0.40 log units) below; low and high end bracket the measured number.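

Moving from the 2,4,6-trifluorophenyl group to the 2-fluoro-3-(trifluoromethyl)phenyl group gives a 7.4-fold higher number from compound 3 to compound 4 (0.87 log units; beyond the scatter) in this assay, the first step at this position whose full size can be read. Against the other two aryl groups only a floor can be read, an at least 1.9-fold lower number from compound 2 to compound 4 (0.29 log units; that floor lies within the scatter) and an at least 1.9-fold lower number from compound 1 to compound 4 (0.29 log units; that floor lies within the scatter), so compound 4 is not shown to stand clearly apart from them. Those floors go no further because compounds 1 and 2 give limits, not numbers: the limit of > 100000 nM in this assay, at which 2 of the 4 values shown sit.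

From the compounds shown here alone, the whole substitution pattern on the ring changes in compound 4, so it remains open whether the trifluoromethyl group or the change in the other fluorines accounts for the step. Also open, going by these compounds, is how a plain phenyl ring, or a phenyl ring carrying a nitrile or a methoxy group, would read at this place.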